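A few compounds are considered here, and "the series" means these few. Any claim that something is new, unique, unknown or untested is made for them only; others in the source may bear on it.

The set holds four compounds on two closely related cores. Compound 1 `COc1cc2ncnc(NNC(=S)NC(=O)c3ccc(C)cc3)c2cc1OC` and compound 2 `COc1cc2ncnc(NNC(=S)NC(=O)c3ccc(C(F)(F)F)cc3)c2cc1OC` share one core and differ in a single place: compound 1 carries a methyl where compound 2 carries a trifluoromethyl, the change being (methyl in place of trifluoromethyl on an aromatic carbon). In a functional assay on GLC82 cells (Homo sapiens) for cytotoxicity, read by MTT assay, with a stated time of 72 h (on this read-out lower numbers stand for stronger inhibition and higher numbers for weaker inhibition), compound 2 gives 16500 nM, and compound 1 gives 29900 nM. The step between them, a 1.8-fold higher number from compound 2 to compound 1 (0.26 log units; within the scatter), shows that this exchange moved the read-out little.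

Compound 3 `O=C(NC(=S)NNc1ncnc2ccccc12)c1ccc(C(F)(F)F)cc1` carries the other core with the trifluoromethyl in place; the difference between the two cores is not broken down here. In this assay compound 3 gives 12200 nM; its gap to compound 2 lies within the scatter, while its gap to compound 1 lies beyond it.

Compound 4 `Cc1ccc(C(=O)NC(=S)NNc2ncnc3ccccc23)cc1` has not been measured. It differs from compound 3 by methyl in place of trifluoromethyl on an aromatic carbon, the same change that separates compound 1 from compound 2, made at the same place. Because the earlier step was a 1.8-fold higher number from compound 2 to compound 1 (0.26 log units; within the scatter), a step of about that size is expected here, though with the core of compound 3 this rests on a single measured instance. Compound 4 is therefore expected to give about 20000 nM, in a range from 10000 nM to 45000 nM. The expected step is a 1.6-fold higher number from compound 3 to compound 4 (0.21 log units; within the scatter), anchored on compound 3 and its value of 12200 nM.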

Compound 4, half-maximal inhibitory concentration: 11200 nM
The estimate for compound 4 lay 1.8-fold (0.25 log units) above the measured number, and the stated range covers the measured number.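

On the core of compound 3, the exchange of trifluoromethyl for methyl gives a 1.1-fold lower number from compound 3 to compound 4 (0.04 log units; within the scatter) in this assay, so on this read-out the two compounds cannot be told apart. Set beside the earlier step, the step on this core shows no difference that can be read: the same change on two cores in this assay, a 1.8-fold higher number (0.26 log units; within the scatter) from compound 2 to compound 1 and a 1.1-fold lower number (0.04 log units; within the scatter) from compound 3 to compound 4, 2.0-fold (0.30 log units) apart, within the scatter of two such steps This shows that, on both cores, the exchange leaves a step within the scatter, so the small size of the step carried over from one core to the other; it does not show that the two steps share a direction or an exact size, and it rests on a single pair of compounds per core.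

The compounds shown leave open how this aromatic carbon would respond to an amine, a carboxylic acid or a longer chain, as they carry only methyl and trifluoromethyl there. They also leave open whether the same small step would appear on a third core or in other cells, and what separates the two cores from each other.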